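The source may report more compounds than this note shows. Statements on the series, on what has been measured and on what is new or still open speak of the compounds shown alone.

Compound 1 `O=C(O)CC/C=C\CC1COC(c2ccc([N+](=O)[O-])cc2)OC1c1cccnc1`: 933 nM
Compound 2 `CC(C)(Oc1ccccc1[N+](=O)[O-])C1OCC(C/C=C\CCC(=O)O)C(c2cccnc2)O1`: 11.2 nM

Both were tested in a functional assay for inhibition, with Homo sapiens as the target; a lower number here means tighter binding, a higher number weaker binding. Compound 1 has the highest of the two numbers; compound 2 sits lower by a margin beyond the usual scatter. Compound 3 `CC(C)(Sc1ccccc1)C1OCC(C/C=C\CCC(=O)O)C(c2cccnc2)O1` has not yet been measured. It differs from compound 1 in one place: a group of 10 heavy atoms (9 carbon, 1 sulfur; one six-membered aromatic ring of carbon only) in place of a group of 9 heavy atoms (6 carbon, 1 nitrogen, 2 oxygen; one six-membered aromatic ring of carbon only), on a saturated ring carbon. Among the compounds with values here, no measured pair covers this exact change. Because compound 2, which also carries another group in place of the 4-nitrophenyl, gives 11.2 nM in this assay, a sizeable drop is expected for compound 3, a 27-fold lower number from compound 1 to compound 3 (1.43 log units; beyond the scatter). Compound 3 is estimated at 35 nM, in the range 8 nM to 160 nM.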

Compound 3, dissociation constant: 200 nM
Compound 3: middle estimate off by 5.7-fold (0.76 log units), on the low side; measured number above the stated range.
By their numbers in this assay, from the lowest: compound 2; then compound 3; then compound 1.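

On the saturated ring carbon between two ring oxygen atoms, replacing 4-nitrophenyl with the branched phenylsulfanyl group gives a 4.7-fold lower number from compound 1 to compound 3 (0.67 log units; beyond the scatter), so a lower number here does not depend on a nitro group. Within that branched group, phenylsulfanyl in place of 2-nitrophenoxy gives an 18-fold higher number from compound 2 to compound 3 (1.25 log units; beyond the scatter), which shows that the end of the group still matters greatly. Nothing measured here explains either step. Sulfur replaces oxygen and the nitro group goes in the same exchange, so their contributions remain unseparated. A plain phenoxy or a 2-nitrophenylsulfanyl group would tell them apart.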